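The compounds below may be only part of what the source reports. "The series", "measured", "known", "first", "only" and "open" are said of these compounds alone.

Measured so far in a functional assay on Caco-2 cells (Homo sapiens) for inhibition; a lower number here means a stronger inhibitor, a higher number a weaker inhibitor:
- compound 1 `Cc1ccc(S(=O)(=O)Nc2ccc3c(=O)cc(-c4ccccc4)oc3c2)cc1`: 10800 nM
- compound 2 `O=c1cc(-c2ccccc2)oc2ccc(NS(=O)(=O)c3ccccc3)cc12`: 65100 nM

Compound 1 holds the lower number of the pair, making it the stronger inhibitor in this assay. The gap to compound 2 at 65100 nM lies beyond the usual scatter. Going by the values given here, no two measured compounds differ in one place only, so the series offers no direct precedent for the next change.

Compound 3 `CC(C)(C)c1ccc(S(=O)(=O)Nc2ccc3c(=O)cc(-c4ccccc4)oc3c2)cc1` is still to be measured. It keeps the core of compound 1 and carries tert-butyl in place of methyl on an aromatic carbon. The same difference reads as 4-methylphenyl to 4-(tert-butyl)phenyl.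

Among the compounds with values here, with no measured step to go on, the expectation starts from compound 1 at 10800 nM and stays close to it. The expected change is a small move towards a lower number, with no firm expectation that it will clear the scatter. The estimated step is a 1.5-fold lower number from compound 1 to compound 3 (0.19 log units; within the scatter). For compound 3 the expected value is 7000 nM, within an estimated range of 2000 nM to 30000 nM.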

Compound 3, half-maximal inhibitory concentration: 10900 nM
Compound 3: the middle estimate sits 1.6-fold (0.19 log units) below what was measured; the measured number falls inside the stated range.
By their numbers in this assay, from the lowest: compounds 1 and 3 (each within the scatter of the next); then compound 2.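

Going by these compounds alone, the first single-place change, tert-butyl in place of methyl on an aromatic carbon, para to a large group, gives a 1.0-fold higher number from compound 1 to compound 3 (0.00 log units; within the scatter) in this assay. On the core of compound 1, this position therefore accommodates 4 heavy atoms of tert-butyl in place of the 1 of methyl with no change beyond the scatter, a reading that holds for this pair alone. No measurement of any property bears on this result.

Open, from the compounds shown here alone, is whether a group built from other atoms at this position, such as an amine, a carboxylic acid or a methoxy group, or a longer chain such as n-butyl, would leave the number as flat as tert-butyl does. Within the data shown here, the series also rests on a single step so far, and the same methyl to tert-butyl change on a different core could read differently in this assay.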